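The source may hold more compounds than are shown below. What is called first, only, known or untested is meant among the compounds shown, and "the series" means these compounds.

Measured so far:
Compound 1 `CN(C)CCCCCCCOc1ccc2oc(-c3ccccc3)cc(=O)c2c1` gives 165 nM in an assay on isolated protein (Cavia porcellus) with Sigma non-opioid intracellular receptor 1 (Homo sapiens) as the target, read by radioligand binding; a higher number here means a weaker inhibitor, a lower number a stronger inhibitor.
Compound 2 `CN(CCCCCCOc1ccc2oc(-c3ccccc3)cc(=O)c2c1)Cc1ccccc1` gives 52 nM in this assay.

Compound 1 stands at the higher of the two numbers; the step to compound 2 is a 3.2-fold lower number from compound 1 to compound 2 (0.50 log units; beyond the scatter). Compound 3 `CCOC(=O)C1CCN(CCCCCCOc2ccc3oc(-c4ccccc4)cc(=O)c3c2)CC1` differs from compound 1 by 4-(ethoxycarbonyl)piperidin-1-yl in place of (dimethylamino)methyl on a saturated chain carbon, six bonds along the chain from an oxygen on an aromatic ring. Among the compounds with values here, only one measured step bears on this change, and it was modest. Because a different amine entering at the same place gave a 3.2-fold lower number from compound 1 to compound 2 (0.50 log units; beyond the scatter), a modest decrease in this assay is expected here too, though the new group is not the same. Compound 3 is therefore estimated at 70 nM, within 25 nM to 250 nM, an expected step of a 2.4-fold lower number from compound 1 to compound 3 (0.37 log units; beyond the scatter).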

Compound 3, half-maximal inhibitory concentration: 164 nM
Compound 3: the middle estimate sits 2.3-fold (0.37 log units) below what was measured; low and high end bracket the measured number.
By their numbers in this assay, from the lowest: compound 2; then compounds 3 and 1 (each within the scatter of the next).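

The earlier step suggested that a new amine at this place lowers the number, but in this assay the much larger 4-(ethoxycarbonyl)piperidin-1-yl gives a 1.0-fold lower number from compound 1 to compound 3 (0.00 log units; within the scatter). Against benzyl(methyl)amino, the same group gives a 3.2-fold higher number from compound 2 to compound 3 (0.50 log units; beyond the scatter), so among these three compounds only compound 2 stands apart. No available evidence explains this difference.

The compounds shown leave open whether the ethoxycarbonyl group matters to this result, which plain piperidin-1-yl or 4-carboxypiperidin-1-yl at the same place could test. They also leave open whether a 4-benzylpiperidin-1-yl group would match compound 2.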